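Dropping a Para Fluorine: Expected Vero Cell Toxicity

This account rests on a few compounds, and the source may have more. Where it says the series, first, only, none or still open, it means among the compounds named here.

Measured so far:
Compound 1 `Fc1ccc(-c2nn3c(NC4CCCC4)cccc3c2-c2ccnc(NC3CCCC3)n2)cc1` gives > 160000 nM in an ADME assay on Vero cells (Chlorocebus sabaeus) for cytotoxicity (on this read-out lower numbers stand for higher toxicity in this test and higher numbers for lower toxicity in this test), a limit of the assay.
Compound 2 `Oc1ccc(-c2nn3c(NC4CCCC4)nccc3c2-c2ccnc(NC3CCCC3)n2)cc1` gives 27000 nM in this assay.
Compound 3 `c1ccc(-c2nn3c(NC4CCCC4)nc(NC4CCCC4)nc3c2-c2ccnc(NC3CCCC3)c2)cc1` gives > 40000 nM in this assay, again a limit.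

Compound 1 stands at a limit, (the limit of > 160000 nM in this assay, at which 1 of the 3 values shown sits), so its half-maximal cytotoxic concentration is known only as a bound, not a number. Compound 3 likewise sits at a limit, (the limit of > 40000 nM in this assay, at which 1 of the 3 values shown sits). Among the measured compounds shown here, no two measured compounds differ in just one place, so no measured step shows how a single change shifts this read-out.

Compound 4 `c1ccc(-c2nn3c(NC4CCCC4)cccc3c2-c2ccnc(NC3CCCC3)n2)cc1` differs from compound 1 by hydrogen in place of fluoro on an aromatic carbon. Such a small change is expected to move this assay by nothing beyond the scatter, giving an expected step of a number no higher from compound 1 to compound 4 (the limit leaves the size open). Compound 4 is therefore expected near 160000 nM, within 50000 nM to 500000 nM, most likely reported again as a limit.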

Compound 4, half-maximal cytotoxic concentration: > 40000 nM
Compound 4 gave a limit, no number; the forecaster's own chance of this, stated with the estimate: 70%; the middle value lies beyond the limit too.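

Compound 1 and compound 4 each give only a limit in this assay, not a number, so the step between them cannot be read. The compounds shown leave open whether going from 4-fluorophenyl to phenyl shifts this read-out at all.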